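Lengthening the Hydroxamic Acid Chain on Two Different Cores

A few compounds are considered here, and "the series" means these few. Any claim that something is new, unique, unknown or untested is made for them only; others in the source may bear on it.

Compound 1 `Nc1nc2cc(-c3nn(CCCC(=O)NO)c4ncnc(N)c34)ccc2o1` gives 19500 nM in a functional assay on MDA-MB-231 cells (Homo sapiens) for inhibition, read by MTT assay, with a stated time of 72 h; a higher number here means a weaker inhibitor, a lower number a stronger inhibitor.
Compound 2 `Nc1nc2cc(-c3nn(CCC(=O)NO)c4ncnc(N)c34)ccc2o1` gives > 50000 nM, a limit of the assay rather than a number.
Compound 3 `Nc1ncnc2c1c(-c1cnc3[nH]ccc3c1)nn2CCC(=O)NO` gives > 150000 nM, likewise a limit rather than a number.

Compounds 1 and 2 share one core and differ in a single place: (hydroxycarbamoyl)methyl in place of hydroxycarbamoyl on a saturated chain carbon, two bonds along the chain from an aromatic nitrogen. That change produced an at least 2.5-fold lower number from compound 2 to compound 1 (0.40 log units; beyond the scatter). Compound 2 sits at the limit of > 50000 nM in this assay, at which 1 of the 3 values shown sits, so only the direction and a lower bound of the step are known.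

Compound 3 carries a different core; the difference between the two cores is not broken down here. Compound 3 sits at the limit of > 150000 nM in this assay, at which 1 of the 3 values shown sits, the weaker end of what the assay reports.

Compound 4 `Nc1ncnc2c1c(-c1cnc3[nH]ccc3c1)nn2CCCC(=O)NO` is made from compound 3 by the same change: (hydroxycarbamoyl)methyl in place of hydroxycarbamoyl on a saturated chain carbon, two bonds along the chain from an aromatic nitrogen. Since this is the same change that separated compound 2 from compound 1, the expectation for compound 4 is a step in the same direction, though starting from a limit rather than a number. The expected step is estimated at an at least 1.8-fold lower number from compound 3 to compound 4 (0.27 log units; that floor lies within the scatter), resting on an at least 2.5-fold lower number from compound 2 to compound 1 (0.40 log units; beyond the scatter) and on the limit of > 150000 nM in this assay, at which 1 of the 3 values shown sits, of compound 3. Compound 4 is therefore expected to give about 80000 nM, within a range from 20000 nM to 250000 nM, and a fair chance remains that the assay again reports only a limit.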

Compound 4, half-maximal inhibitory concentration: > 150000 nM
Compound 4: no number, only a limit; the forecaster's own chance of this, stated with the estimate: 45%; middle value at least 1.8-fold (0.27 log units) away from the limit.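

In this assay compound 4 gives > 150000 nM, which is a limit and not a number. Compound 3 stands at the same limit, so no step between compound 3 and compound 4 can be read: the limit of > 150000 nM in this assay, at which 2 of the 4 values shown sit.

Left open is how weak these two compounds really are, and whether the longer chain changes anything at all on the core they share.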